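Urea series: a second chloro enters the aromatic ring

A few compounds are considered here, and "the series" means these few. Any claim that something is new, unique, unknown or untested is made for them only; others in the source may bear on it.

Compound 1 `C[C@H](NC(=O)Nc1ccccc1Cl)c1ccccc1` gives 99% in an ADME assay on the whole organism with Oryza sativa as the target, tested at 0.1 uM; on this read-out lower numbers stand for a stronger effect and higher numbers for a weaker effect at the one concentration tested. Compound 2 `C[C@H](NC(=O)Nc1ccccc1Br)c1ccccc1` gives 101% in this assay, and compound 3 `C[C@H](NC(=O)Nc1ccccc1I)c1ccccc1` gives 99%. The steps among them are small: a number 2 percentage points higher from compound 1 to compound 2 (within the scatter), no change at the digits printed from compound 1 to compound 3 (within the scatter), a number 2 percentage points lower from compound 2 to compound 3 (within the scatter). Compound 1 thus sits at the same digits as compound 3, and its gap to compound 2 lies within the scatter, so none of the three stands apart from the others in this assay.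

Compound 4 `C[C@H](NC(=O)Nc1cccc(Cl)c1Cl)c1ccccc1` differs from compound 1 by chloro in place of hydrogen on an aromatic carbon. Each measured step exchanges one halogen for another on the aromatic carbon; none puts a group where hydrogen stood, so they bear on this step only in showing that the read-out in this assay has not moved beyond the scatter anywhere in the series. The step expected in this assay is therefore no change at the digits printed from compound 1 to compound 4 (within the scatter), nothing beyond the scatter. Compound 4 is estimated at 99% in this assay, with a range from 89% to 109%.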

Compound 4, a percentage reported as activity, at one concentration (the size of the read-out at that concentration, not a potency): 100%
Compound 4: middle estimate off by 1 percentage points, on the low side, and the stated range covers the measured number.
By their numbers in this assay, from the lowest: compounds 1, 3, 4 and 2 (each within the scatter of the next).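

Chloro in place of hydrogen is the first step in the series that adds a group at a position where hydrogen stood, rather than exchanging one halogen for another, and in this assay it reads as a number 1 percentage points higher from compound 1 to compound 4 (within the scatter). The aromatic carbon ortho to a chloro group and meta to a large group therefore accepts a second chloro without a step beyond the scatter, at least in the setting of compound 1. No supporting measurement bears on why this step reads as it does.

As far as these compounds go, what a methoxy, an amine or a carboxylic acid would give on this same aromatic carbon remains open. Also open, from the compounds shown here alone, is whether any single change to the shared core can move this read-out beyond the scatter.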